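A Dimethylamino Swap in a Cytotoxicity Series

This account rests on a few compounds, and the source may have more. Where it says the series, first, only, none or still open, it means among the compounds named here.

The three measured compounds share one core and differ at a single aromatic carbon. Compound 1 `c1ccc(-c2ccc(Cn3cncc3CNc3ccc(-c4ccccc4)c(-c4ccccc4)c3)cc2)cc1` carries a phenyl there. In a toxicity assay on NIH3T3 cells (Mus musculus) for cytotoxicity, read by resazurin assay (a higher number here means that more compound is needed for the effect, a lower number that less compound is needed), compound 1 gives > 10000 nM, which is a limit of the assay and not a number. Compound 2 `c1ccc(-c2ccc(Cn3cncc3CNc3ccc(-c4cncs4)c(-c4ccccc4)c3)cc2)cc1` carries a 1,3-thiazol-5-yl instead. In this assay compound 2 gives > 1000 nM, again a limit rather than a number. Compound 3 `CNC(=O)c1ccc(NCc2cncn2Cc2ccc(-c3ccccc3)cc2)cc1-c1ccccc1` carries a methylcarbamoyl. In this assay compound 3 gives > 1000 nM, also a limit. Compound 3 thus stands at the limit of > 1000 nM in this assay, at which 2 of the 3 values shown sit, together with compound 2, while compound 1 sits at the limit of > 10000 nM in this assay, at which 1 of the 3 values shown sits. All three values are limits, so the steps between them cannot be read: a step that the two limits leave unreadable from compound 1 to compound 2, a step that the two limits leave unreadable from compound 1 to compound 3 and a step that the two limits leave unreadable from compound 2 to compound 3.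

Among the compounds with values here, compound 4 `CN(C)c1ccc(NCc2cncn2Cc2ccc(-c3ccccc3)cc2)cc1-c1ccccc1` is the compound not yet measured. dimethylamino in place of methylcarbamoyl on an aromatic carbon The only steps that bear on this change are the three above, and none of them has a readable size. Within the data shown here, nothing among the measured compounds points to a direction beyond the scatter. Compound 4 is therefore expected to stay close to where its neighbours sit, with an estimated step that the limit leaves unreadable from compound 3 to compound 4. The estimated value for compound 4 is 5000 nM, with a range from 1000 nM to 30000 nM.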

Compound 4, half-maximal effective concentration: > 1000 nM
Compound 4: no number, only a limit; the forecaster's own chance of this, stated with the estimate: 70%; the middle value lies beyond the limit too.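

In this assay compound 4 gives > 1000 nM, which is a limit of the assay and not a number. The steps to compound 4 from compound 1, compound 2 and compound 3 cannot be read. The compounds shown leave open how much of any of the four compounds is needed for the effect, and whether swapping the group on this aromatic carbon changes that amount at all.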